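Swapping the aryl group on the hydrazone carbon

The source may hold more compounds than are shown below. What is called first, only, known or untested is meant among the compounds shown, and "the series" means these compounds.

Measured compounds:
- compound 1 `O=C(CSc1nnc(-c2ccncc2)o1)N/N=C/c1ccccc1` gives 167000 nM
- compound 2 `O=C(CSc1nnc(-c2ccncc2)o1)N/N=C/c1ccc(Br)cc1` gives 169000 nM
- compound 3 `COc1cccc(/C=N/NC(=O)CSc2nnc(-c3ccncc3)o2)c1` gives 179000 nM

All three share one core and differ only in the aryl ring on the carbon with a double bond to nitrogen. In an ADME assay on NIH3T3 cells (Mus musculus) for cytotoxicity, read by MTT assay, with a stated time of 24 h (a higher number here means a weaker inhibitor, a lower number a stronger inhibitor), compound 3 sits alongside the other two: the steps of a 1.1-fold higher number from compound 1 to compound 3 (0.03 log units; within the scatter) and a 1.1-fold higher number from compound 2 to compound 3 (0.02 log units; within the scatter) are both within the scatter, as is a 1.0-fold higher number from compound 1 to compound 2 (0.01 log units; within the scatter). Compound 4 `O=C(CSc1nnc(-c2ccncc2)o1)N/N=C/c1cc(Cl)cc(Cl)c1O` carries the change (3,5-dichloro-2-hydroxyphenyl in place of 3-methoxyphenyl on a carbon with a double bond to nitrogen). The two earlier changes at this ring moved nothing beyond the scatter, so no step beyond it is expected here either, estimated as a 1.1-fold lower number from compound 3 to compound 4 (0.02 log units; within the scatter). For compound 4 the expected value is 170000 nM, within a range of 85000 nM to 340000 nM.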

Compound 4, half-maximal inhibitory concentration: 171000 nM
Compound 4: middle estimate off by 1.0-fold (0.00 log units), on the low side; the range from low to high includes it.
By their numbers in this assay, from the lowest: compounds 1, 2, 4 and 3 (each within the scatter of the next).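

The 3,5-dichloro-2-hydroxyphenyl ring goes further than the earlier swaps, bringing chlorine atoms and a hydrogen-bond donor that 3-methoxyphenyl lacks. Even so, this assay does not separate compound 4 from the other three (a 1.0-fold lower number from compound 3 to compound 4 (0.02 log units; within the scatter); a 1.0-fold higher number from compound 2 to compound 4 (0.01 log units; within the scatter); a 1.0-fold higher number from compound 1 to compound 4 (0.01 log units; within the scatter)), so all of these steps stay within the scatter and this position has so far tolerated every aryl change shown. From the compounds shown here alone, whether an aryl ring carrying an amine or a carboxylic acid, or a longer chain on the same carbon, would shift the number remains open. Nothing available explains why these aryl changes leave the number in place.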